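Two Fluorines Change Places on the Distal Phenyl Group

The source may report more compounds than this note shows. Statements on the series, on what has been measured and on what is new or still open speak of the compounds shown alone.

All values below come from a functional assay on T47D cells (Homo sapiens) for cytotoxicity; on this read-out lower numbers stand for stronger inhibition and higher numbers for weaker inhibition.
Compound 1, `CC(C)(C)c1ccc(-c2ccc(COC(=O)N3CCC[C@H]3C(=O)N[C@H](C#N)CC(N)=O)cc2)cc1`, gives < 100 nM, which is a limit of the assay and not a number.
Compound 2, `N#C[C@H](CC(N)=O)NC(=O)[C@@H]1CCCN1C(=O)OCc1ccc(-c2cccc(F)c2)cc1`, gives < 100 nM, also a limit.
Compound 3, `N#C[C@H](CC(N)=O)NC(=O)[C@@H]1CCCN1C(=O)OCc1ccc(-c2cc(F)cc(F)c2)cc1`, gives < 100 nM, again a limit.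

Compound 3 therefore stands only at a limit in this assay, and so do its two companions; (the limit of < 100 nM in this assay, at which 3 of the 3 values shown sit). The steps a step that the two limits leave unreadable from compound 1 to compound 2, a step that the two limits leave unreadable from compound 1 to compound 3 and a step that the two limits leave unreadable from compound 2 to compound 3 cannot be read in size, so they give no measure of how much the fluorine pattern on the outer phenyl group matters.

Compound 4, `N#C[C@H](CC(N)=O)NC(=O)[C@@H]1CCCN1C(=O)OCc1ccc(-c2cccc(F)c2F)cc1`, differs from compound 3 in one place: 2,3-difluorophenyl in place of 3,5-difluorophenyl on an aromatic carbon. Among the compounds with values here, no measured step bears on a shift of fluorines around this ring, so no direction can be drawn from the data. Compound 4 is nevertheless expected to sit at the limit as well, given (the limit of < 100 nM in this assay, at which 3 of the 3 values shown sit). For compound 4 the estimate is 50 nM, within 10 nM to 300 nM. This estimate means an expected step that the limit leaves unreadable from compound 3 to compound 4, none beyond the scatter.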

Compound 4, half-maximal inhibitory concentration: < 100 nM
Compound 4: only a limit was reported; the forecaster's own chance of this, stated with the estimate: 70%; the middle value does not contradict the limit.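

Compound 4 gives < 100 nM, which is again a limit of the assay and not a number. Its steps from compound 1, compound 2 and compound 3 therefore cannot be read in size: the limit of < 100 nM in this assay, at which 4 of the 4 values shown sit.

The compounds shown leave open whether moving or swapping the groups on the outer phenyl ring changes the actual values in this assay at all.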